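Azide linker lengthening across two related cores

The compounds below may be only part of what the source reports. "The series", "measured", "known", "first", "only" and "open" are said of these compounds alone.

Measured so far:
compound 1 `CCNC(=O)Nc1ccc(-c2nc3n(Cc4c(F)cccc4F)cc(C(=O)OCC)c(=O)n3c2CN(CC(=O)NCc2cn(CCOCCOCCN=[N+]=[N-])nn2)Cc2ccccc2)cc1` gives 468 nM
compound 2 `CCNC(=O)Nc1ccc(-c2nc3n(Cc4c(F)cccc4F)cc(C(=O)OCC)c(=O)n3c2CN(CC(=O)NCc2cn(CCOCCOCCOCCN=[N+]=[N-])nn2)Cc2ccccc2)cc1` gives 724 nM
compound 3 `CCOC(=O)c1cn(Cc2c(F)cccc2F)c2nc(-c3ccc(NC(=O)NCc4cn(CCOCCN=[N+]=[N-])nn4)cc3)c(CN(C)Cc3ccccc3)n2c1=O` gives 3630 nM

The read-out throughout is a functional assay on CHO cells for antagonist activity at Gonadotropin-releasing hormone receptor (Homo sapiens), read by a luciferase reporter, with a stated time of 30 min; a lower number here means a stronger inhibitor, a higher number a weaker inhibitor. Compound 1 and compound 2 differ by 2-azidoethoxy in place of azido on a saturated chain carbon, two bonds along the chain from an oxygen on a saturated carbon, and the step of a 1.5-fold higher number from compound 1 to compound 2 (0.19 log units; within the scatter) tells how little this changes the number. Compound 3 carries a different core; the difference between the core of compound 1 and the core of compound 3 is not broken down here, and its number stands beyond the scatter from both compound 1 and compound 2.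

Compound 4 `CCOC(=O)c1cn(Cc2c(F)cccc2F)c2nc(-c3ccc(NC(=O)NCc4cn(CCOCCOCCN=[N+]=[N-])nn4)cc3)c(CN(C)Cc3ccccc3)n2c1=O` is the not yet measured partner of compound 3. The change is 2-azidoethoxy in place of azido on a saturated chain carbon, two bonds along the chain from an oxygen on a saturated carbon, the same change as that from compound 1 to compound 2, with the same surroundings at the place of the change. Among the measured compounds shown here, the step of a 1.3-fold higher number from compound 3 to compound 4 (0.12 log units; within the scatter) is expected to be small because a 1.5-fold higher number from compound 1 to compound 2 (0.19 log units; within the scatter) stayed within the scatter, though only one earlier instance is available and the core of compound 3 is a different one. On that basis compound 4 is estimated at 4800 nM, with an expected range from 2000 nM to 11000 nM.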

Compound 4, half-maximal inhibitory concentration: 2400 nM
For compound 4 the middle estimate is 2.0-fold (0.30 log units) above the measured one, and the stated range covers the measured number.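

In this assay, putting 2-azidoethoxy in place of azido on the core of compound 3 gives a 1.5-fold lower number from compound 3 to compound 4 (0.18 log units; within the scatter), a step too small to read as a real change. Set beside the earlier instance, the same change shows no difference between the two cores that stands out from the scatter: the same change on two cores in this assay, a 1.5-fold higher number (0.19 log units; within the scatter) from compound 1 to compound 2 and a 1.5-fold lower number (0.18 log units; within the scatter) from compound 3 to compound 4, 2.3-fold (0.37 log units) apart, within the scatter of two such steps This rests on two pairs only: no direction can be read from either step, and nothing here shows that the change would stay this small on any other core.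

The compounds shown leave open whether a longer chain on the core of compound 3, or an amine or a carboxylic acid in place of azido, would stay as close in this assay. Among the compounds shown here, no pair here isolates a single difference between the core of compound 1 and the core of compound 3, so the contribution of each part of that difference remains unresolved.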